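Two difluorophenyl patterns: compound 2 to compound 3

The source may hold more compounds than are shown below. What is called first, only, known or untested is meant among the compounds shown, and "the series" means these compounds.

Measured in a physicochemical assay for lipophilicity, read by LC-MS, measured as octanol-water partition, with a stated time of 18 h, at pH 7.4; on this read-out higher numbers stand for higher lipophilicity and lower numbers for lower lipophilicity:
Compound 1 `O=C(CCCN1CCCCCC1)Nc1nnc(-c2ccc(F)cc2)s1`: 1.97
Compound 2 `O=C(CCCN1CCCCCC1)Nc1cnc(-c2ccc(F)cc2F)s1`: 2.11

Compound 2, at 2.11, lies within the usual scatter of compound 1, so these two numbers cannot be told apart. Compound 3 `O=C(CCCN1CCCCCC1)Nc1cnc(-c2ccc(F)c(F)c2)s1` has the same atoms as compound 2, joined differently, with 3,4-difluorophenyl in place of 2,4-difluorophenyl on an aromatic carbon. For the measured compounds named here, no two measured compounds differ in only one place, so no measured step offers a guide. In this assay, no step beyond the scatter is expected. The expected change is a number 0.09 log units higher from compound 2 to compound 3 (within the scatter). Compound 3 is estimated at 2.2, with an expected range of 1.85 to 2.55.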

Compound 3, distribution coefficient: 2.3
Compound 3: the middle estimate sits 0.10 log units below what was measured, within the range that was stated.
By their numbers in this assay, from the lowest: compounds 1, 2 and 3 (each within the scatter of the next, the first and the last beyond it).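

In this assay, for the compounds shown here, the swap of 2,4-difluorophenyl for 3,4-difluorophenyl on this aromatic carbon gives a number 0.19 log units higher from compound 2 to compound 3 (within the scatter) and is the first single-place comparison in this set. Moving the fluorines around this phenyl ring, with the same atoms kept, therefore produces no difference that can be separated from the scatter of repeated measurements. Nothing available explains the size of this step.

From the compounds shown here alone, whether chlorine or methoxy groups in place of the fluorines would shift the number beyond the scatter remains open. Also open, going by these compounds, is whether the same swap would behave alike on a different core.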